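Aryl substituent swap on the shared core: fluoro to methyl

A few compounds are considered here, and "the series" means these few. Any claim that something is new, unique, unknown or untested is made for them only; others in the source may bear on it.

Compound 1 `COC(=O)c1cc(-c2csc(N/N=C/c3cccs3)n2)ccc1OCc1ccccc1` and compound 2 `Fc1ccc(-c2csc(N/N=C/c3ccc(Cl)cc3Cl)n2)cc1` have been measured in a functional assay, read by spectrophotometry, with a stated time of 15 min, tested at 60 ug/mL; on this read-out lower numbers stand for a weaker effect and higher numbers for a stronger effect at the one concentration tested. In this assay compound 1 gives 95.5%. In this assay compound 2 gives 94.6%. Compound 2 holds the lower of the two numbers, yet the gap to compound 1 lies within the usual scatter, so no order between the two can be read. Among the compounds with values here, no step between compounds differing in a single place is available here, since compound 1 and compound 2 differ from each other in more than one place.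

Compound 3 `Cc1ccc(-c2csc(N/N=C/c3ccc(Cl)cc3Cl)n2)cc1` is not yet measured. It differs from compound 2 in one place: methyl in place of fluoro on an aromatic carbon. The exchange sits on an aromatic carbon of a six-membered aromatic ring of carbon only, reading as 4-fluorophenyl to 4-methylphenyl when cut one bond further out.

Within the data shown here, with no measured single-point step to lean on, and both measured numbers sitting close to the top of the read-out, the step of a number 1.6 percentage points lower from compound 2 to compound 3 (within the scatter) is expected to stay within the scatter. The estimate for compound 3 in this assay is 93%, with a range from 80% to 98%.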

Compound 3, a percentage reported as inhibition, at one concentration (the size of the read-out at that concentration, not a potency): 93.3%
For compound 3 the middle estimate is 0.3 percentage points below the measured one; the measured number falls inside the stated range.
By their numbers in this assay, from the lowest: compounds 3, 2 and 1 (each within the scatter of the next).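

In this assay, the exchange of fluoro for methyl on an aromatic carbon, para to a large group, gives a number 1.3 percentage points lower from compound 2 to compound 3 (within the scatter). Within the data shown here, this is the first reading of a change at one place, as the earlier pair differs in more than one place and could not isolate any single group. At this position on the shared core, 4-fluorophenyl and 4-methylphenyl cannot be told apart on this read-out at the one concentration tested, and no measurement available here explains that result.

On these data alone, whether an amine, a carboxylic acid or a longer chain such as propyl at this same place would give a step beyond the scatter remains open. Also open, as far as these compounds go, is whether compound 2 and compound 3 would separate at a lower concentration, as a single-concentration read-out gives the size of the effect and not a potency.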